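Anilino ring substituent series: hydroxy in place of bromo

This account rests on a few compounds, and the source may have more. Where it says the series, first, only, none or still open, it means among the compounds named here.

Three measured compounds share one core and differ only in the group on the aromatic ring that sits on the amine. Compound 1 `C=C1[C@@H](OC(C)=O)C[C@@H]2[C@](C)(CO[Si](C)(C)C(C)(C)C)[C@H](OC(C)=O)CC[C@@]2(C)[C@@H]1C[C@@H](Nc1ccccc1)C1=CCOC1=O` carries the unsubstituted ring; in a functional assay on MCF7 cells (Homo sapiens) for cytotoxicity, read by sulforhodamine B assay (a lower number here means a stronger inhibitor, a higher number a weaker inhibitor), compound 1 gives 4840 nM. Compound 2 `C=C1[C@@H](OC(C)=O)C[C@@H]2[C@](C)(CO[Si](C)(C)C(C)(C)C)[C@H](OC(C)=O)CC[C@@]2(C)[C@@H]1C[C@@H](Nc1ccc(OC)cc1)C1=CCOC1=O` carries a methoxy, and in this assay compound 2 gives 4280 nM. Compound 3 `C=C1[C@@H](OC(C)=O)C[C@@H]2[C@](C)(CO[Si](C)(C)C(C)(C)C)[C@H](OC(C)=O)CC[C@@]2(C)[C@@H]1C[C@@H](Nc1ccc(Br)cc1)C1=CCOC1=O` carries a bromo, and in this assay compound 3 gives 3920 nM. Compound 3 has the lowest of the three numbers, but every gap to it lies within the scatter: a 1.2-fold lower number from compound 1 to compound 3 (0.09 log units; within the scatter) and a 1.1-fold lower number from compound 2 to compound 3 (0.04 log units; within the scatter), as does a 1.1-fold lower number from compound 1 to compound 2 (0.05 log units; within the scatter). The three substituents therefore cannot be told apart on these numbers.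

Compound 4 `C=C1[C@@H](OC(C)=O)C[C@@H]2[C@](C)(CO[Si](C)(C)C(C)(C)C)[C@H](OC(C)=O)CC[C@@]2(C)[C@@H]1C[C@@H](Nc1ccc(O)cc1)C1=CCOC1=O` is the next member. The change from compound 3: hydroxy in place of bromo on an aromatic carbon. Within the data shown here, the steps that bear on it are the three substituent exchanges on that ring, each within the scatter, so a fourth exchange at the same position is expected to give no step beyond the scatter in this assay. The expected step is a 1.1-fold higher number from compound 3 to compound 4 (0.06 log units; within the scatter), that is, effectively none. Compound 4 is accordingly estimated at 4500 nM, with a range from 2500 nM to 8500 nM; the absence of any hydroxy among the measured compounds widens this range.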

Compound 4, half-maximal inhibitory concentration: 5220 nM
Compound 4: the middle estimate sits 1.2-fold (0.06 log units) below what was measured; the range from low to high includes it.
By their numbers in this assay, from the lowest: compounds 3, 2, 1 and 4 (each within the scatter of the next).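

Among these compounds, the hydroxy group is the first substituent to bring a hydrogen-bond donor to the aromatic carbon para to a large group, yet in this assay all three new steps stay within the scatter: against bromo (a 1.3-fold higher number from compound 3 to compound 4 (0.12 log units; within the scatter)), against methoxy, where only the methyl on the oxygen is replaced by hydrogen (a 1.2-fold higher number from compound 2 to compound 4 (0.09 log units; within the scatter)), and against the unsubstituted ring (a 1.1-fold higher number from compound 1 to compound 4 (0.03 log units; within the scatter)). Hydrogen, methoxy, bromo and hydroxy at this position therefore cannot be told apart in this assay, so on these four compounds neither the exchange of bromine for oxygen nor the added donor and acceptor count shows up as a measurable step, and no compound in the set goes against this. No independent measurement is available to explain this lack of response.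

Going by these compounds, it remains open whether a charged or larger group at the same position, such as an amine, a carboxylic acid or a longer chain, would give a step beyond the scatter. Also open, on these data alone, is whether the response stays this flat when the substituent sits elsewhere on the ring or when the shared core is changed.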